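Swapping a Hydroxyl for a Nitro Group on the Side Chain

The source may report more compounds than this note shows. Statements on the series, on what has been measured and on what is new or still open speak of the compounds shown alone.

Compound 1 `O=C(/C=C\c1ccccc1O)N1N=C(c2ccncc2)OC1c1c[nH]c2ccccc12` gives in an ADME assay on PANC-1 cells (Homo sapiens) for cytotoxicity, read by MTT assay, with a stated time of 48 h (a lower number here means a stronger inhibitor of growth, a higher number a weaker inhibitor of growth), the value > 30 ug/mL.
Compound 2 `O=C(/C=C\c1cccc(O)c1)N1N=C(c2ccncc2)OC1c1c[nH]c2ccccc12` gives in this assay the value > 30 ug/mL.

The value of compound 1 is a limit of the assay, not a number. The value of compound 2 is likewise a limit of the assay, not a number. Because of this, the step that the two limits leave unreadable from compound 1 to compound 2 cannot be read, and the evidence on it is only that (the limit of > 30 ug/mL in this assay, at which 2 of the 2 values shown sit). Compound 2 therefore stands at the limit of the assay, and nothing in the numbers separates it from compound 1.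

Compound 3 `O=C(/C=C\c1ccccc1[N+](=O)[O-])N1N=C(c2ccncc2)OC1c1c[nH]c2ccccc12` differs from compound 2 by 2-nitrophenyl in place of 3-hydroxyphenyl on a double-bonded chain carbon bound to a double-bonded chain carbon. Within the data shown here, no measured step involves a nitrophenyl group, and the single measured step is unreadable, so there is no measured guide to the size or direction of this change. With both measured compounds sitting at the limit, the step that the limit leaves unreadable from compound 2 to compound 3 is expected to show no change beyond the scatter, and a further limit is the most likely outcome. Compound 3 is therefore estimated at 40 ug/mL, within a range from 15 ug/mL to 100 ug/mL.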

Compound 3, concentration for 50% growth inhibition: > 30 ug/mL
Compound 3: a limit, no number; the forecaster's own chance of this, stated with the estimate: 70%; the middle value lies beyond the limit too.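

In this assay compound 3 gives > 30 ug/mL as a limit and not a number. Among these compounds, no step among compound 1, compound 2 and compound 3 can be read: (the limit of > 30 ug/mL in this assay, at which 3 of the 3 values shown sit). The compounds shown leave open how strongly each inhibits growth, and whether exchanging hydroxyphenyl for nitrophenyl changes that at all.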